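The source may report more compounds than this note shows. Statements on the series, on what has been measured and on what is new or still open speak of the compounds shown alone.

Measured so far in a functional assay on SJSA-1 cells (Homo sapiens) for inhibition, read by CCK-8 assay, with a stated time of 72 h, tested at 1 uM; on this read-out lower numbers stand for less inhibition and higher numbers for more inhibition at the one concentration tested (going by the name of the read-out):
compound 1 `COc1ccccc1N1C(=O)CSC1C(=O)NCCCCc1ccccc1` gives 14%;
compound 2 `O=C(NCCCCc1ccccc1)c1cccc(C2SCC(=O)N2c2ccccc2)c1` gives 73%;
compound 3 `CCN1C(=O)CSC1c1cccc(C(=O)NCCCCc2ccccc2)c1` gives 3%.

Compound 3 is the lowest of the three numbers in this assay. Among the measured compounds shown here, compound 1 is closest to it, and compound 2 is furthest from it; the step of a number 70 percentage points lower from compound 2 to compound 3 (beyond the scatter) is the one measured change of the ring-nitrogen substituent and it is large, ethyl in place of phenyl on an amide-type nitrogen in a ring.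

Compound 4 `COc1c(F)cccc1N1C(=O)CSC1c1cccc(C(=O)NCCCCc2ccccc2)c1` is not yet measured. It differs from compound 3 by 3-fluoro-2-methoxyphenyl in place of ethyl on an amide-type nitrogen in a ring. This runs opposite to the measured step from compound 2 to compound 3, restoring an aromatic ring on the ring nitrogen, so a large rise in this assay is expected for compound 4, estimated as a number 57 percentage points higher from compound 3 to compound 4 (beyond the scatter). Compound 1, which also carries a methoxyphenyl on the ring nitrogen but on a different core, gives 14%, which tempers the expectation somewhat. The estimate for compound 4 in this assay is 60%, with a range from 30% to 85%.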

Compound 4, a percentage reported as inhibition, at one concentration (the size of the read-out at that concentration, not a potency): 1%
Beside the measured number, compound 4's estimate is 59 percentage points above it; the whole stated range lies above it.
By their numbers in this assay, from the lowest: compounds 4 and 3 (each within the scatter of the next); then compound 1; then compound 2.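

In this assay, an aromatic ring on the amide-type ring nitrogen is not enough on its own to give a high number: 3-fluoro-2-methoxyphenyl in place of ethyl gives a number 2 percentage points lower from compound 3 to compound 4 (within the scatter). In place of phenyl, the same group gives a number 72 percentage points lower from compound 2 to compound 4 (beyond the scatter), so at this position the outcome depends on the substituents on the aromatic ring, not merely on the ring's presence. No evidence at hand accounts for this result.

Open, as far as these compounds go, is whether the methoxy or the fluoro substituent alone matches this drop from compound 2. Also open, from the compounds shown here alone, is how a benzyl group or a pyridine ring on this nitrogen would compare with phenyl.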